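The source may report more compounds than this note shows. Statements on the series, on what has been measured and on what is new or still open speak of the compounds shown alone.

Compound 1 `CCCCCCCCCCc1ccc(-c2noc(C3CNC3)n2)cc1` gives 65% in an assay on HeLa cells for inhibition of sphingosine-1-phosphate transporter SPNS2 (Mus musculus), read by LC-MS, tested at 2 uM; on this read-out lower numbers stand for less inhibition and higher numbers for more inhibition at the one concentration tested (going by the name of the read-out). Compound 2 `CCCCCCCCCCc1ccc(-c2noc(CN)n2)cc1` gives 62%. Compound 3 `CCCCCCCCCCc1ccc(-c2noc(CC3CCNC3)n2)cc1` gives 44%.

Compound 3 holds the lowest of the three numbers: the step from compound 1 is a number 21 percentage points lower from compound 1 to compound 3 (beyond the scatter) and the step from compound 2 is a number 18 percentage points lower from compound 2 to compound 3 (beyond the scatter), both beyond the scatter, whereas a number 3 percentage points lower from compound 1 to compound 2 (within the scatter) stays within it. Compound 4 `CCCCCCCCCCc1ccc(-c2noc([C@@H](N)CCCN)n2)cc1` has not yet been measured. It differs from compound 3 in one place: 1,4-diaminobutyl in place of (pyrrolidin-3-yl)methyl on an aromatic carbon. The step that bears most on this change is a number 18 percentage points lower from compound 2 to compound 3 (beyond the scatter), where a pyrrolidin-3-yl group took the place of an amino group and the number fell; a number 21 percentage points lower from compound 1 to compound 3 (beyond the scatter) points the same way. Compound 4 moves back from the ring to an open chain carrying amines, which resembles compound 2 more than compound 3, so the loss seen in those two steps is expected to be undone at least in part. Compound 4 is therefore estimated to reach 58%, within 42% to 72%. The expected step is a number 14 percentage points higher from compound 3 to compound 4 (beyond the scatter), upward and beyond the scatter, though the longer chain leaves room for it to fall short.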

Compound 4, a percentage reported as inhibition, at one concentration (the size of the read-out at that concentration, not a potency): 40%
Compound 4: the middle estimate sits 18 percentage points above what was measured; the measured number lies below the stated range.
By their numbers in this assay, from the lowest: compounds 4 and 3 (each within the scatter of the next); then compounds 2 and 1 (each within the scatter of the next).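

In this assay, replacing the ring of (pyrrolidin-3-yl)methyl with the open 1,4-diaminobutyl chain, which adds a second amine, makes no readable difference (a number 4 percentage points lower from compound 3 to compound 4 (within the scatter)). Adding 3-aminopropyl to the chain carbon of compound 2 brings a clear loss (a number 22 percentage points lower from compound 2 to compound 4 (beyond the scatter)), and the step from the azetidin-3-yl group is of similar size (a number 25 percentage points lower from compound 1 to compound 4 (beyond the scatter)), so at this aromatic carbon an open chain with amines does not by itself keep the higher numbers. Nothing available here explains this loss.

A 1-aminobutyl group, which lacks the second amine, could show whether the longer chain or that amine matters more here. Going by these compounds, how the mirror-image form of 1,4-diaminobutyl would compare also stays open.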